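Compound 3: a carbonyloxy link replaces the carbamoyl

The source may hold more compounds than are shown below. What is called first, only, known or untested is meant among the compounds shown, and "the series" means these compounds.

In a functional assay on SF-268 cells (Homo sapiens) for inhibition, read by sulforhodamine B assay, with a stated time of 48 h (on this read-out lower numbers stand for stronger inhibition of growth and higher numbers for weaker inhibition of growth), compound 1 `CCCCCCCCCCCC[C@@H](O)[C@H]1CC[C@H]([C@H](O)CCCCCCCCCCNC(=O)c2ccnn2C)O1` gives 100000 nM and compound 2 `CCCCCCCCCCCC[C@@H](O)[C@H]1CC[C@H]([C@H](O)CCCCCCCCCCC(=O)Nc2ccnn2C)O1` gives 100000 nM so compound 2 stands level with compound 1. For the measured compounds named here, compound 3 `CCCCCCCCCCCC[C@@H](O)[C@H]1CC[C@H]([C@H](O)CCCCCCCCCCOC(=O)c2ccnn2C)O1` keeps the shared core and changes one link, with ((1-methyl-1H-pyrazol-5-yl)carbonyl)oxy in place of (1-methyl-1H-pyrazol-5-yl)carbamoyl on a saturated chain carbon, ten or more bonds along the chain from an oxygen on a saturated carbon and a saturated ring carbon as the one difference from compound 2. Going by the values given here, the one measured step on this link shows no change at the digits printed from compound 1 to compound 2 (within the scatter) and no measured compound yet carries the new group. No step beyond the scatter is therefore expected in this assay for this change. The expected step is no change at the digits printed from compound 2 to compound 3 (within the scatter) on this estimate. Compound 3 is estimated at 100000 nM with an expected range (30000 nM to 150000 nM).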

Compound 3, concentration for 50% growth inhibition: 100000 nM
Compound 3: middle estimate and measured number agree at the digits printed; measured number inside the range.
By their numbers in this assay, from the lowest: compounds 1, 2 and 3 (each within the scatter of the next).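

With the carbonyloxy link, the group on this saturated chain carbon carries 0 hydrogen-bond donors, where both amide links carry one, and in this assay the step is no change at the digits printed from compound 2 to compound 3 (within the scatter). Against the other amide orientation the step is no change at the digits printed from compound 1 to compound 3 (within the scatter), so all three links on this chain read alike here. Nothing measured on these compounds offers an explanation for this.

From the compounds shown here alone, it remains open whether an amine or a carboxylic acid at this place would read differently. A longer chain carrying the same pyrazole group is equally unsettled.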